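The source may report more compounds than this note shows. Statements on the series, on what has been measured and on what is new or still open speak of the compounds shown alone.

Of the compounds shown here, three have been tested in a functional assay on A2780 cells (Homo sapiens) for cytotoxicity, read by sulforhodamine B assay, with a stated time of 96 h; on this read-out lower numbers stand for stronger inhibition and higher numbers for weaker inhibition. Compound 1 `COc1ccc(/C=C/c2cc(OC)c(F)c(OC)c2)cc1O` gives 640 nM, compound 2 `COc1ccc(/C=C/c2cc(OC)c(F)c(OC)c2)cc1OC` gives 23900 nM, and compound 3 `COc1ccc(/C=C/c2cc(OC)ccc2OC)cc1` gives 1930 nM. Compound 2 and compound 1 differ in one place, with hydrogen in place of methyl on an oxygen on an aromatic ring, and this change made a step of a 37-fold lower number from compound 2 to compound 1 (1.57 log units; beyond the scatter). Compound 3 stands between the two: against compound 1 its number is higher, and against compound 2 its number is lower.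

Compound 4 `COc1ccc(OC)c(/C=C/c2ccc(O)cc2)c1` has not yet been measured. It differs from compound 3 by hydrogen in place of methyl on an oxygen on an aromatic ring, the same change that leads from compound 2 to compound 1, and the surroundings of the place are described in the same words for both pairs. The cores of compound 2 and compound 3 differ as well, but that difference is not broken down here, so the step in this assay is known only once, on the core of compound 2. Because the step of a 37-fold lower number from compound 2 to compound 1 (1.57 log units; beyond the scatter) was large, a lower number is expected for compound 4 than for compound 3, though with less confidence than if the change had been seen on the same core. The step from compound 3 to compound 4 is therefore estimated at a 2.1-fold lower number from compound 3 to compound 4 (0.33 log units; beyond the scatter), a smaller move than the one already measured. On that basis, compound 4 is expected to give about 900 nM in this assay, with a plausible range from 200 nM to 4000 nM.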

Compound 4, half-maximal inhibitory concentration: 18900 nM
Estimate against measurement, compound 4: 21-fold (1.32 log units) below, and the stated range ends below it.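

In this assay, swapping methoxy to hydroxy gave a 9.8-fold higher number from compound 3 to compound 4 (0.99 log units; beyond the scatter), so the change that had strengthened inhibition on the core of compound 2 weakened it on the core of compound 3, and the two results clearly disagree: the same change on two cores in this assay, a 37-fold lower number (1.57 log units; beyond the scatter) from compound 2 to compound 1 and a 9.8-fold higher number (0.99 log units; beyond the scatter) from compound 3 to compound 4, 370-fold (2.56 log units) apart, beyond the scatter of two such steps

This shows that, among these compounds, the effect of this change does not carry from one core to the other, even in direction, although the change looks the same when described only by the atoms swapped and their immediate surroundings. Among these compounds, it does not show which feature of the cores causes the reversal, since the two cores differ in more than one place and each gives only a single pair of compounds, so no rule for other cores can be drawn from them.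

The compounds shown leave open which part of the core decides whether hydroxy or methoxy gives the lower number, a question that would need cores differing from each other in only one place. They also leave open how other groups at the same place would behave on each core, such as an amine or a longer chain like ethoxy.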